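A few compounds are considered here, and "the series" means these few. Any claim that something is new, unique, unknown or untested is made for them only; others in the source may bear on it.

Compound 1 `CC(C(=O)NCc1ccc(C(F)(F)F)nc1NC1CCCCC1)c1ccc(NS(C)(=O)=O)c(F)c1`: 20.4 nM
Compound 2 `CC(C(=O)NCc1ccc(C(F)(F)F)nc1N1CCCC1)c1ccc(NS(C)(=O)=O)c(F)c1`: 0.6 nM

In a functional assay on CHO-K1 cells for antagonist activity at transient receptor potential cation channel subfamily V member 1 (Homo sapiens), read by FLIPR (on this read-out lower numbers stand for stronger inhibition and higher numbers for weaker inhibition), compound 1 gives 20.4 nM, while compound 2 gives 0.6 nM. Among the measured compounds shown here, compound 2 therefore stands at the lowest of the two numbers, and its nearest neighbour is compound 1, reached by a 34-fold lower number from compound 1 to compound 2 (1.53 log units; beyond the scatter), the only measured step in the set.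

Compound 3 `CC(C(=O)NCc1ccc(C(F)(F)F)nc1N1CCCCC1C)c1ccc(NS(C)(=O)=O)c(F)c1` differs from compound 2 in one place: 2-methylpiperidin-1-yl in place of pyrrolidin-1-yl on an aromatic carbon. For the measured compounds named here, the one measured step, a 34-fold lower number from compound 1 to compound 2 (1.53 log units; beyond the scatter), bears on this change only in part: it exchanged a cyclohexylamino group for a pyrrolidin-1-yl group and was large, whereas the step to compound 3 keeps a ring nitrogen bound to the aromatic carbon and changes the size and substitution of that ring. Going by the values given here, no measured pair shows what such a change does, so the account rests on that single step alone. A modest rise is expected in this assay for compound 3, smaller than the measured step, because the large fall in a 34-fold lower number from compound 1 to compound 2 (1.53 log units; beyond the scatter) accompanied the move to a ring nitrogen, which compound 3 retains. The expected step is a 3.3-fold higher number from compound 2 to compound 3 (0.52 log units; beyond the scatter). Compound 3 is accordingly estimated at 2 nM, within a range of 0.5 nM to 10 nM.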

Compound 3, inhibition constant: 2.9 nM
Beside the measured number, compound 3's estimate is 1.5-fold (0.16 log units) below it, and the stated range covers the measured number.
By their numbers in this assay, from the lowest: compound 2; then compound 3; then compound 1.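

In this assay, the position next to the ring nitrogen proves sensitive to which ring it carries, not only to whether the group is cyclic and bound through its own nitrogen: 2-methylpiperidin-1-yl in place of pyrrolidin-1-yl gives a 4.8-fold higher number from compound 2 to compound 3 (0.68 log units; beyond the scatter). Compound 3 nevertheless keeps much of the advantage over the cyclohexylamino group, with a 7.0-fold lower number from compound 1 to compound 3 (0.85 log units; beyond the scatter), so both groups bound through a ring nitrogen lie below cyclohexylamino among these compounds, and none of the three goes against that order. Nothing available explains why either of these steps has its size.

The step from compound 2 to compound 3 enlarges the ring and adds a methyl group at once, so the shares of the two changes stay unseparated; piperidin-1-yl without the methyl, or 2-methylpyrrolidin-1-yl, would divide them. Going by these compounds, it also remains open how this position would respond to a ring with a second hetero atom, such as morpholin-4-yl, or to an open-chain amine such as dimethylamino.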